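The compounds below may be only part of what the source reports. "The series", "measured", "known", "first", "only" and "open" are said of these compounds alone.

Among the measured compounds shown here, in a functional assay on DU-145 cells (Homo sapiens) for antiproliferative activity (on this read-out higher numbers stand for weaker inhibition and lower numbers for stronger inhibition), compound 1 `CNc1cc(-c2ccc3cnn(Cc4cc(OC)cc(OC)c4)c3c2)cn(C)c1=O` gives 2600 nM and compound 2 `CNc1cc(-c2ccc3cnn(Cc4ccc(F)c(F)c4)c3c2)cn(C)c1=O` gives 4800 nM, so compound 2 stands within the scatter of the only other measured compound. Compound 3 `CNc1cc(-c2ccc3cnn(Cc4ccc(F)c([N+](=O)[O-])c4)c3c2)cn(C)c1=O` differs from compound 2 at one place: nitro in place of fluoro on an aromatic carbon. In words, nitro replaces fluoro on an aromatic carbon, turning 3,4-difluorophenyl into 4-fluoro-3-nitrophenyl. For the measured compounds named here, only one measured step bears on this, a 1.8-fold higher number from compound 1 to compound 2 (0.27 log units; within the scatter), which put 3,4-difluorophenyl in place of 3,5-dimethoxyphenyl on the same saturated chain carbon and stayed within the scatter. Going by the values given here, no measured compound carries a nitro group, so this is thin evidence, and no step beyond the scatter is expected in this assay. The expected change is a 1.2-fold lower number from compound 2 to compound 3 (0.08 log units; within the scatter). For compound 3 the estimated value is 4000 nM, with an expected range of 1500 nM to 11000 nM.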

Compound 3, half-maximal inhibitory concentration: 3400 nM
Compound 3: the middle estimate sits 1.2-fold (0.07 log units) above what was measured; the range from low to high includes it.
By their numbers in this assay, from the lowest: compounds 1, 3 and 2 (each within the scatter of the next).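

In this assay, nitro on the aromatic carbon ortho to a fluoro group, with 3 heavy atoms and 2 hydrogen-bond acceptors where fluoro has 1 heavy atom and none, leaves the read-out within the scatter (a 1.4-fold lower number from compound 2 to compound 3 (0.15 log units; within the scatter)). The step that exchanges 3,5-dimethoxyphenyl for 4-fluoro-3-nitrophenyl is also within the scatter (a 1.3-fold higher number from compound 1 to compound 3 (0.12 log units; within the scatter)), so all three aryl groups on this saturated chain carbon now stand within the scatter of one another. No supporting measurement explains why these exchanges leave the read-out so little changed.

On these data alone, it remains open whether an amine or a carboxylic acid on this ring, or a longer chain in place of the single chain carbon, would give a step beyond the scatter. As far as these compounds go, it is also open whether any position on the shared core would respond more strongly.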